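A piperidine in place of the ester on the shared core

The compounds below may be only part of what the source reports. "The series", "measured", "known", "first", "only" and "open" are said of these compounds alone.

Measured in a functional assay on cells (Homo sapiens), read by thymidine incorporation; a higher number here means a weaker inhibitor, a lower number a stronger inhibitor:
compound 1 `Cc1cc(NCc2cccnc2)n2ncc(Br)c2n1`: 1800 nM
compound 2 `CCOC(=O)c1cc(NCc2cccnc2)n2ncc(Br)c2n1`: 2900 nM
compound 3 `Brc1cnn2c(NCc3cccnc3)cc(C3CCCNC3)nc12`: 60 nM

Compound 2 stands with compound 1 at the weak end of this small set. The gap between them, a 1.6-fold higher number from compound 1 to compound 2 (0.21 log units; within the scatter), lies within the scatter, whereas a 48-fold lower number from compound 2 to compound 3 (1.68 log units; beyond the scatter) lies beyond it.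

The step followed here leads to compound 4 `Brc1cnn2c(NCc3cccnc3)cc(C3CCNCC3)nc12`, which carries piperidin-4-yl in place of ethoxycarbonyl on an aromatic carbon.

Within the data shown here, two measured steps bear on this change. The closest is a 48-fold lower number from compound 2 to compound 3 (1.68 log units; beyond the scatter), large and beyond the scatter, where piperidin-3-yl replaces the same ethoxycarbonyl. The other is a 30-fold lower number from compound 1 to compound 3 (1.48 log units; beyond the scatter), also large, where piperidin-3-yl replaces methyl. Among the measured compounds shown here, compound 4 carries piperidin-4-yl rather than piperidin-3-yl, and no measured pair shows what that difference does. For the measured compounds named here, a large step to a lower number is therefore expected in this assay, of similar size to the one that gave compound 3, with real uncertainty on either side. The expected step is a 32-fold lower number from compound 2 to compound 4 (1.51 log units; beyond the scatter). For compound 4 the estimate is 90 nM, with an expected range from 25 nM to 350 nM.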

Compound 4, half-maximal inhibitory concentration: 160 nM
Estimate against measurement, compound 4: 1.8-fold (0.25 log units) below, within the range that was stated.
By their numbers in this assay, from the lowest: compound 3; then compound 4; then compounds 1 and 2 (each within the scatter of the next).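

In this assay, the large gain at this position does not depend on a single attachment of the piperidine ring. Piperidin-4-yl also gives a large drop against the ester, with an 18-fold lower number from compound 2 to compound 4 (1.26 log units; beyond the scatter), and against the methyl group, with an 11-fold lower number from compound 1 to compound 4 (1.05 log units; beyond the scatter). Among these compounds, the attachment point still matters, which no earlier pair could show: the move from piperidin-3-yl to piperidin-4-yl gives a 2.7-fold higher number from compound 3 to compound 4 (0.43 log units; beyond the scatter), a modest step but one beyond the scatter, leaving compound 3 with the lowest number of the four. Nothing available here explains why either piperidine gives a lower number than ethoxycarbonyl or methyl, or why the two attachments differ.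

From the compounds shown here alone, what a cyclohexyl ring, with carbon in place of the piperidine nitrogen, would give at this position remains open. So does the outcome with a smaller pyrrolidin-3-yl ring or an open aminoethyl chain, either of which would help show how much of the piperidine the lower numbers require.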